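This account rests on a few compounds, and the source may have more. Where it says the series, first, only, none or still open, it means among the compounds named here.

Measured compounds:
compound 1, `Cc1nn(-c2ncnc3nc[nH]c23)c2c1C(OCC(=O)c1ccc(F)cc1)CC(=O)N2`: 3 nM
compound 2, `Cc1nn(-c2ncnc3nc[nH]c23)c2c1C(C(=O)NCc1ccccc1)CC(=O)N2`: 5 nM

In a functional assay on HEK293 cells for agonist activity at G-protein coupled receptor 39 (Homo sapiens), read by scintillation proximity assay and inositol phosphate accumulation, with a stated time of 75 min, in the presence of a further agent that is not named here (a lower number here means that less compound is needed, a higher number that more compound is needed for the effect), compound 1 gives 3 nM and compound 2 gives 5 nM; compound 2 stands alongside compound 1, the gap between the two lying within the scatter. Compound 3, `Cc1nn(-c2ncnc3nc[nH]c23)c2c1C(C(=O)N(C)c1ccccc1)CC(=O)N2`, has not been measured. It differs from compound 2 by methyl(phenyl)amino in place of benzylamino on a carbonyl carbon. Among the compounds with values here, no measured pair in this set shows a change of this kind, so its size is open. The expected step is a 3.0-fold higher number from compound 2 to compound 3 (0.48 log units; beyond the scatter), a moderate rise in the number, beyond the scatter. Compound 3 is estimated at 15 nM, within a range from 4 nM to 60 nM.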

Compound 3, half-maximal effective concentration: 32 nM
The estimate for compound 3 lay 2.1-fold (0.33 log units) below the measured number; the measured number falls inside the stated range.
By their numbers in this assay, from the lowest: compounds 1 and 2 (each within the scatter of the next); then compound 3.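

In this assay, within the data shown here, the step shows that this carbonyl position is sensitive to how its substituent is built, which the earlier compounds did not show. Methyl(phenyl)amino in place of benzylamino gives a 6.4-fold higher number from compound 2 to compound 3 (0.81 log units; beyond the scatter), although both groups have the same heavy atoms and the same aromatic ring. The swap also removes the amide hydrogen and joins the ring directly to the nitrogen, and this single pair cannot separate those two differences.

Phenylamino or methyl(benzyl)amino on the same carbonyl remains open as a way to tell them apart. Nothing available explains the step.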